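From 4-bromophenyl to 3,4-dimethoxyphenyl on the shared core

A few compounds are considered here, and "the series" means these few. Any claim that something is new, unique, unknown or untested is made for them only; others in the source may bear on it.

Going by the values given here, in a functional assay on MCF7 cells (Homo sapiens) for cytotoxicity, read by MTT assay, with a stated time of 48 h (on this read-out lower numbers stand for stronger inhibition and higher numbers for weaker inhibition), compound 2 `COc1cc(-n2c(-c3ccc(Br)cc3)cn(C(C)=O)c2=O)cc(OC)c1OC` gives 10600 nM, the only actual number so far. Compound 1 `COc1ccc(-c2cn(C(=O)Nc3cc(OC)c(OC)c(OC)c3)c(=O)n2-c2cc(OC)c(OC)c(OC)c2)cc1OC` reads > 50000 nM, which is a limit of the assay. Compound 3 `COc1ccc(-c2cn(C(C)=O)c(=O)n2-c2cc(OC)c(OC)c(OC)c2)cc1OC` carries 3,4-dimethoxyphenyl in place of 4-bromophenyl on an aromatic carbon. Among the compounds with values here, no measured step between compounds differing in one place is available, so the call is a judgement: a modest weakening in this assay, possibly not far beyond the scatter. The expected change is a 1.5-fold higher number from compound 2 to compound 3 (0.18 log units; within the scatter). Compound 3 is estimated at 16000 nM, with an expected range of 5000 nM to 45000 nM.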

Compound 3, half-maximal inhibitory concentration: > 50000 nM
Compound 3: a limit, no number (the forecaster's own chance of this, stated with the estimate: 25%); at least 3.1-fold (0.49 log units) between middle value and limit.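

Going by these compounds alone, on the aromatic carbon of the shared core, 3,4-dimethoxyphenyl in place of 4-bromophenyl gives the first readable step in this assay: an at least 4.7-fold higher number from compound 2 to compound 3 (0.67 log units; beyond the scatter). This shows that the read-out at this position responds to the aryl group, with 4-bromophenyl the only one here that gives a number. The value for compound 3 is a limit, so the step has no upper end: the limit of > 50000 nM in this assay, at which 2 of the 3 values shown sit.

Still open, on these data alone, is how 4-fluorophenyl, 4-methoxyphenyl or 4-aminophenyl at this carbon would read. Which part of the change, the loss of bromine or the entry of the two methoxy groups, drives the step also remains open.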